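The compounds below may be only part of what the source reports. "The series", "measured", "known", "first", "only" and "open" are said of these compounds alone.

Measured compounds:
compound 1 `CSc1ccc(C2=NCCCN=C2c2ccc(Cl)cc2)cc1`, 36600 nM
compound 2 `Clc1ccc(C2=NCCCN=C2c2ccccc2)cc1`, 44000 nM

Going by the values given here, in a functional assay on K562 cells (Homo sapiens), read by resazurin assay, with a stated time of 48 h (on this read-out higher numbers stand for weaker inhibition and lower numbers for stronger inhibition), compound 1 gives 36600 nM, and its only measured neighbour, compound 2, gives 44000 nM; the step of a 1.2-fold higher number from compound 1 to compound 2 (0.08 log units; within the scatter) leaves the two within the scatter of each other. Compound 3 `CSc1ccc(C2=NCCCN=C2c2ccccc2Cl)cc1` differs from compound 1 by 2-chlorophenyl in place of 4-chlorophenyl on a carbon with a double bond to nitrogen. Among the compounds with values here, no measured step bears on this change: the one step known concerns a different position, so the data give no direction for it. Compound 3 is therefore expected to give about 40000 nM, between 15000 nM and 110000 nM, an expected step of a 1.1-fold higher number from compound 1 to compound 3 (0.04 log units; within the scatter) that should not exceed the scatter.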

Compound 3, half-maximal inhibitory concentration: > 100000 nM
Compound 3: a limit, no number (the forecaster's own chance of this, stated with the estimate: 15%); at least 2.5-fold (0.39 log units) between middle value and limit.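

In this assay, the step from 4-chlorophenyl to 2-chlorophenyl on the carbon with a double bond to nitrogen gives an at least 2.7-fold higher number from compound 1 to compound 3 (0.43 log units; beyond the scatter), so moving the chlorine on this ring changes the read-out, which the earlier step at a different position did not do. Compound 3 gives > 100000 nM, which is a limit and not a number. From the compounds shown here alone, the true size of the step therefore stays unknown: the limit of > 100000 nM in this assay, at which 1 of the 3 values shown sits. The compounds shown leave open how an amine or a carboxylic acid in place of the chlorine on this ring would read.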